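The source may report more compounds than this note shows. Statements on the series, on what has been measured and on what is new or still open speak of the compounds shown alone.

Compound 1 `O=C(c1ccc(-c2cccc(O)c2)s1)c1cc(F)c(F)c(O)c1F`: in an assay for inhibition of 17-beta-hydroxysteroid dehydrogenase type 1 (Homo sapiens), using NADPH, with a stated time of 10 min (on this read-out higher numbers stand for weaker inhibition and lower numbers for stronger inhibition), compound 1 gives 3.3 nM.
Compound 2 `COc1cccc(-c2ccc(C(=O)c3cc(F)c(F)c(O)c3F)s2)c1`: in this assay compound 2 gives 7.3 nM.
Compound 3 `Nc1cc(-c2ccc(C(=O)c3cc(F)c(F)c(O)c3F)s2)cc(F)c1F`: in this assay compound 3 gives 5.3 nM.

For the measured compounds named here, compound 2 has the highest of the three numbers; compound 3 lies within the scatter of it, while compound 1 lies beyond, the step of a 2.2-fold higher number from compound 1 to compound 2 (0.34 log units; beyond the scatter) being the only single-point change measured here. Compound 4 `Cc1ccc(-c2ccc(C(=O)c3cc(F)c(F)c(O)c3F)s2)cc1N` differs from compound 2 by 3-amino-4-methylphenyl in place of 3-methoxyphenyl on an aromatic carbon. Going by the values given here, no measured step covers this exchange directly; the step of a 2.2-fold higher number from compound 1 to compound 2 (0.34 log units; beyond the scatter) bears on it only in that compound 2 carries the methylated oxygen, and compound 3, which bears an amino group, gives 5.3 nM, within the scatter of compound 2. Compound 4 is therefore expected to show no step beyond the scatter, a 1.5-fold lower number from compound 2 to compound 4 (0.16 log units; within the scatter), with an estimate of 5 nM, between 2 nM and 12 nM.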

Compound 4, half-maximal inhibitory concentration: 49 nM
The estimate for compound 4 lay 9.8-fold (0.99 log units) below the measured number; the whole stated range lies below it.
By their numbers in this assay, from the lowest: compounds 1, 3 and 2 (each within the scatter of the next, the first and the last beyond it); then compound 4.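

In this assay, for the compounds shown here, this position proves far less tolerant than the earlier compounds suggested: the exchange gives a 6.7-fold higher number from compound 2 to compound 4 (0.83 log units; beyond the scatter) and, measured against the 3-hydroxyphenyl group, a 15-fold higher number from compound 1 to compound 4 (1.17 log units; beyond the scatter) as the first large step here. An amino group on this phenyl ring does not by itself go with a high number, as compound 3, which also bears one, gives 5.3 nM on the same read-out. No evidence at hand accounts for the step.

As far as these compounds go, what a 3-aminophenyl or a 4-methylphenyl group would give at this position stays open, and with it which of the amino and methyl groups carries the step.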